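Working notes: aryl swap from compound 2 to compound 4

The source may report more compounds than this note shows. Statements on the series, on what has been measured and on what is new or still open speak of the compounds shown alone.

Measured so far in a functional assay on BMDM cells (Mus musculus, strain C57BL/6) for inhibition, with a stated time of 2 days; a higher number here means a weaker inhibitor, a lower number a stronger inhibitor:
- compound 1 `Cc1cc(NC(=O)Cn2cc(-c3ccc([N+](=O)[O-])cc3)nn2)no1`: 1220 nM
- compound 2 `CCOC(=O)c1sc(NC(=O)Cn2cc(-c3cccs3)nn2)nc1C`: 20 nM
- compound 3 `Cc1csc(NC(=O)Cn2cc(-c3cccs3)nn2)n1`: 40 nM

Compound 2 gives the lowest number of the three in this assay. For the measured compounds named here, compound 3 stands nearest to it, and the one step between measured compounds that differ in a single place, a 2.0-fold higher number from compound 2 to compound 3 (0.30 log units; within the scatter), lies within the scatter. Compound 1 stands furthest from compound 2, but it differs from compound 2 in more than one place, so only its two values can be set side by side, and they show a gap beyond the scatter.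

The unmeasured compound 4 `CCOC(=O)c1sc(NC(=O)Cn2cc(-c3ccc(OC)cc3)nn2)nc1C` is derived from compound 2 by the change (4-methoxyphenyl in place of thiophen-2-yl on an aromatic carbon). Going by the values given here, no measured step touches this group: the one step that exists, a 2.0-fold higher number from compound 2 to compound 3 (0.30 log units; within the scatter), concerns the ethoxycarbonyl on the other ring and is within the scatter, and compound 1 carries a different core together with a different aryl group, so it cannot isolate the aryl swap. For this assay the expectation is therefore a step of uncertain direction, most likely within or only slightly beyond the scatter. The expected step is a 2.0-fold higher number from compound 2 to compound 4 (0.30 log units; within the scatter). Compound 4 is estimated at 40 nM, with a range from 10 nM to 160 nM.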

Compound 4, half-maximal inhibitory concentration: 2330 nM
Compound 4: middle estimate off by 58-fold (1.77 log units), on the low side; measured number outside the range, above it.
By their numbers in this assay, from the lowest: compounds 2 and 3 (each within the scatter of the next); then compounds 1 and 4 (each within the scatter of the next).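

In this assay, for the compounds shown here, the swap of thiophen-2-yl for 4-methoxyphenyl on the aromatic carbon of the five-membered aromatic ring with 3 nitrogen gives a 120-fold higher number from compound 2 to compound 4 (2.07 log units; beyond the scatter) and provides the first single-place reading at this position. Going by these compounds alone, the only earlier single-place step, a 2.0-fold higher number from compound 2 to compound 3 (0.30 log units; within the scatter), concerned the ethoxycarbonyl on the other ring and lay within the scatter, so this position is the first where one change moves the number beyond the scatter. Hydrogen-bond donor and acceptor counts and net charge stay the same across the swap, while the heavy atoms go from 5 to 8 and a five-membered ring with 1 hetero atom gives way to a six-membered ring of carbon only, so ring type, size and the methoxy group all change in one step.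

Still open, on these data alone, is which of these matters, which a plain phenyl, a furan-2-yl or a 4-methylphenyl group on the same carbon would begin to separate, along with whether the step carries over to the core of compound 3. No measurement shown here accounts for the size of the step.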